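Working notes: from compound 2 to compound 3

The source may report more compounds than this note shows. Statements on the series, on what has been measured and on what is new or still open speak of the compounds shown alone.

In a functional assay on A549 cells (Homo sapiens) for antiproliferative activity, read by MTT assay (a higher number here means a weaker inhibitor, a lower number a stronger inhibitor), compound 2 (`COc1cc2c(Oc3ccc(NC(=O)Nc4ccc(C)cc4C)cc3)ccnc2cc1OCCCCCCC(=O)NO`) gives 5490 nM and lies within the scatter of compound 1 (`COc1cc2c(Oc3ccc(NC(=O)Nc4ccc(OC(F)(F)F)cc4)cc3)ccnc2cc1OCCCCCCC(=O)NO`) at 3130 nM with no other number available. Among the compounds with values here, the only measured step, a 1.8-fold higher number from compound 1 to compound 2 (0.24 log units; within the scatter) on the same amide-type nitrogen, stays within the scatter. Within the data shown here, compound 3 (`COc1cc2c(Oc3ccc(NC(=O)N/N=C/c4ccc(F)cc4)cc3)ccnc2cc1OCCCCCCC(=O)NO`) changes that place again (a group of 9 heavy atoms (7 carbon, 1 nitrogen, 1 fluorine; one six-membered aromatic ring of carbon only) in place of a group of 8 heavy atoms (8 carbon; one six-membered aromatic ring of carbon only), on an amide-type nitrogen) and no measured step covers a group of this kind. With so little evidence, no shift beyond the scatter is expected. The expected change is a 1.3-fold lower number from compound 2 to compound 3 (0.12 log units; within the scatter) and it stays within the scatter. The estimate for compound 3 is 4200 nM with an expected range of 1300 nM to 13000 nM in this read-out.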

Compound 3, half-maximal inhibitory concentration: 4920 nM
Compound 3: middle estimate off by 1.2-fold (0.07 log units), on the low side; low and high end bracket the measured number.
By their numbers in this assay, from the lowest: compounds 1, 3 and 2 (each within the scatter of the next).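

In this assay, the group entering on the amide-type nitrogen brings a nitrogen, a fluorine and a double bond outside aromatic rings, yet the outcome is a 1.1-fold lower number from compound 2 to compound 3 (0.05 log units; within the scatter) and a 1.6-fold higher number from compound 1 to compound 3 (0.20 log units; within the scatter). This place has now carried three different groups, and the numbers of all three compounds lie within the scatter of one another. No available evidence bears on this result.

Going by these compounds, whether an amine or a carboxylic acid on this nitrogen would give a shift beyond the scatter remains open. On these data alone, what a shorter chain on the shared core would do also remains open.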